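This account rests on a few compounds, and the source may have more. Where it says the series, first, only, none or still open, it means among the compounds named here.

Measured so far in an assay for binding affinity to dual specificity mitogen-activated protein kinase kinase 4 (Homo sapiens), read by KINOMEscan, tested at 100 nM; a lower number here means a stronger effect, a higher number a weaker effect of the compound at the concentration tested:
- compound 1 `CCCS(=O)(=O)Nc1ccc(F)c(C(=O)c2n[nH]c3ncc(-c4ccc(F)cc4)cc23)c1F`: 2.1%
- compound 2 `CCCS(=O)(=O)Nc1ccc(F)c(C(=O)c2n[nH]c3ncc(-c4ccc(O)cc4)cc23)c1F`: 0.75%
- compound 3 `CCCS(=O)(=O)Nc1ccc(F)c(C(=O)c2n[nH]c3ncc(-c4ccc(C(C)(C)C)cc4)cc23)c1F`: 46%

Among these three numbers compound 1 stands second highest. Its nearest neighbour is compound 2, and that gap, a number 1.4 percentage points lower from compound 1 to compound 2 (within the scatter), lies within the scatter, so the two cannot be told apart. The furthest is compound 3, reached by a number 43.9 percentage points higher from compound 1 to compound 3 (beyond the scatter), a large step beyond the scatter; the same large step is seen from compound 2, a number 45.3 percentage points higher from compound 2 to compound 3 (beyond the scatter).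

Compound 4 `CCCS(=O)(=O)Nc1ccc(F)c(C(=O)c2n[nH]c3ncc(-c4ccc(F)cc4C)cc23)c1F` differs from compound 1 by methyl in place of hydrogen on an aromatic carbon. The fluoro group of compound 1 is kept; the 4-fluorophenyl becomes a 4-fluoro-2-methylphenyl, the methyl sitting ortho to a large group and meta to the fluoro.

Among the measured compounds shown here, none of the measured steps adds a group while keeping the fluoro: all three exchange the fluoro itself for hydroxy or tert-butyl. They show that a small exchange of the group on that carbon left the number within the scatter, while a bulkier one raised it greatly. A methyl is a small addition, so the step of a number 3.9 percentage points higher from compound 1 to compound 4 (within the scatter) is expected to be small, most likely within the scatter, with some chance of a modest rise. Compound 4 is therefore estimated at 6%, within 0.8% to 35%.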

Compound 4, a percentage reported as activity, at one concentration (the size of the read-out at that concentration, not a potency): 14%
For compound 4 the middle estimate is 8 percentage points below the measured one; the range from low to high includes it.
By their numbers in this assay, from the lowest: compounds 2 and 1 (each within the scatter of the next); then compound 4; then compound 3.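

In this assay, compound 4 is the first case shown that keeps the fluoro and adds a group to the ring, and the single methyl gives a number 11.9 percentage points higher from compound 1 to compound 4 (beyond the scatter), so even one added carbon at this position, ortho to a large group, can shift the number beyond the scatter. The shift remains much smaller than the gap to the tert-butyl compound, a number 32 percentage points lower from compound 3 to compound 4 (beyond the scatter), while the hydroxy compound still lies clearly on the stronger side, a number 13.3 percentage points higher from compound 2 to compound 4 (beyond the scatter), which places compound 4 between the two, although the methyl and the groups it is compared with do not sit on the same carbon. Nothing available here explains why the added methyl raises the number.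

From the compounds shown here alone, it remains open whether a chlorine, a methoxy or an ethyl group on the same carbon would raise the number further or less than the methyl does. Going by these compounds, it is also open whether the methyl would have a similar effect on a ring carrying the hydroxy of compound 2 instead of the fluoro.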